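The compounds below may be only part of what the source reports. "The series", "measured", "known", "first", "only" and "open" are said of these compounds alone.

Within the data shown here, in an ADME assay on Huh-7 cells (Homo sapiens) for cytotoxicity, read by MTT assay, with a stated time of 48 h (a lower number here means that less compound is tolerated, a higher number that more compound is tolerated), compound 1 `CN(C)CCCCOC(=O)Nc1ccc(Cn2nc(-c3ccncc3)c3ccccc3c2=O)cc1` gives 62700 nM, the highest number among the three compounds measured so far. Compound 2 `CN(C)CCCCOC(=O)Nc1ccc(Cn2nc(-c3cnn(C)c3)c3ccccc3c2=O)cc1` gives 55900 nM, and compound 3 `CN(C)CCCCOC(=O)Nc1ccc(Cn2nc(-c3cccc(C#N)c3)c3ccccc3c2=O)cc1` gives 17200 nM. Compound 4 `CN(C)CCCCOC(=O)Nc1ccc(Cn2nc(-c3ccccc3C(F)(F)F)c3ccccc3c2=O)cc1` differs from compound 1 by 2-(trifluoromethyl)phenyl in place of pyridin-4-yl on an aromatic carbon. Among the measured compounds shown here, two measured steps bear on this change: a 1.1-fold lower number from compound 1 to compound 2 (0.05 log units; within the scatter), and a 3.6-fold lower number from compound 1 to compound 3 (0.56 log units; beyond the scatter). The second of these, which likewise brings in a six-membered aromatic ring of carbon only in place of pyridin-4-yl, is the closer analogy, so a modest drop beyond the scatter is expected for compound 4 in this assay, namely a 2.5-fold lower number from compound 1 to compound 4 (0.40 log units; beyond the scatter). Compound 4 is therefore estimated at 25000 nM, with a range from 10000 nM to 60000 nM.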

Compound 4, half-maximal cytotoxic concentration: 35700 nM
Compound 4: middle estimate off by 1.4-fold (0.15 log units), on the low side; measured number inside the range.
By their numbers in this assay, from the lowest: compound 3; then compounds 4, 2 and 1 (each within the scatter of the next).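

In this assay, a six-membered aromatic ring of carbon only at this position does not by itself bring the drop seen with compound 3: a 1.8-fold lower number from compound 1 to compound 4 (0.24 log units; within the scatter) stays within the scatter, and a 1.6-fold lower number from compound 2 to compound 4 (0.19 log units; within the scatter) does as well. Instead, a 2.1-fold higher number from compound 3 to compound 4 (0.32 log units; beyond the scatter) sets compound 3 apart, so among these compounds the lower number goes with 3-cyanophenyl and not with the loss of the ring nitrogen. Nothing given here explains this difference. As far as these compounds go, it remains open whether an unsubstituted phenyl would sit nearer compound 3 or compound 4, and how a phenyl ring carrying an amine or a carboxylic acid would behave at this position.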